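Sulfonyl Aryl Swaps on a Shared Benzylamide Core

The source may hold more compounds than are shown below. What is called first, only, known or untested is meant among the compounds shown, and "the series" means these compounds.

Measured compounds:
compound 1 `Cc1ccccc1C(=O)NCc1ccc(CNS(=O)(=O)c2ccc(F)cc2)cc1` gives 10 nM
compound 2 `Cc1ccccc1C(=O)NCc1ccc(CNS(=O)(=O)c2cccc3ccccc23)cc1` gives 100 nM
compound 3 `Cc1ccccc1C(=O)NCc1ccc(CNS(=O)(=O)c2ccc([N+](=O)[O-])cc2)cc1` gives 100 nM

All three share one core and differ only in the group on the sulfonyl sulfur. In an assay on MDA-MB-231 cells for displacement of a labelled ligand from C-X-C chemokine receptor type 4 (Homo sapiens), read by fluorescence and microscopy, with stated times of 10 min and 30 min (a lower number here means that less compound is needed, a higher number that more compound is needed for the effect), compound 3 gives 100 nM, level with compound 2, and together these two give the highest numbers among the three; the step of a 10-fold higher number from compound 1 to compound 3 (1.00 log units; beyond the scatter) sets compound 3 well apart from compound 1.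

Compound 4 `Cc1ccccc1C(=O)NCc1ccc(CNS(=O)(=O)c2cccc(F)c2)cc1` has not yet been measured. The change from compound 3 is 3-fluorophenyl in place of 4-nitrophenyl on a sulfonyl sulfur. The step that bears on it is a 10-fold higher number from compound 1 to compound 3 (1.00 log units; beyond the scatter), since it exchanges fluoro for nitro on the same kind of ring; the step of no change at the digits printed from compound 2 to compound 3 (within the scatter) adds nothing in either direction. Reversing the nitro-for-fluoro exchange should bring the number back down, though compound 4 carries a 3-fluorophenyl rather than the 4-fluorophenyl of compound 1, and no measured pair shows what that alone does. Compound 4 is therefore expected to give a lower number, a step of about a 5.0-fold lower number from compound 3 to compound 4 (0.70 log units; beyond the scatter), estimated at 20 nM within a range of 7 nM to 60 nM.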

Compound 4, effective concentration (reported as EC, without a stated level of effect): 100 nM
Estimate against measurement, compound 4: 5.0-fold (0.70 log units) below; measured number outside the range, above it.
By their numbers in this assay, from the lowest: compound 1; then compounds 2, 3 and 4 (each within the scatter of the next).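

Moving the fluorine alone, with 3-fluorophenyl in place of 4-fluorophenyl on the sulfonyl sulfur, gives a 10-fold higher number from compound 1 to compound 4 (1.00 log units; beyond the scatter) in this assay and so shows that carrying a fluorine does not by itself keep the low number of compound 1. Compound 4 instead sits with the other two, with no change at the digits printed from compound 3 to compound 4 (within the scatter) and no change at the digits printed from compound 2 to compound 4 (within the scatter) as the printed steps, which leaves compound 1 as the only one of the four set apart. Nothing measured here gives a reason for this difference.

Still open, on these data alone, is whether a chlorophenyl or a methoxyphenyl on the sulfonyl sulfur would sit with compound 1 or with the other three. A plain methyl there would show whether an aromatic ring is needed at all.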